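The source may hold more compounds than are shown below. What is called first, only, known or untested is meant among the compounds shown, and "the series" means these compounds.

In an assay on CHO cells for positive allosteric modulation of adenosine receptor A1 (Homo sapiens), read by ERK phosphorylation, tested at 3 uM (a higher number here means a weaker effect of the compound at the concentration tested, a lower number a stronger effect), compound 3 `Nc1sc(-c2ccccc2)cc1C(=O)c1ccc(Cl)cc1` gives 46%, the second highest of the three numbers. Compound 1 `Nc1sccc1C(=O)c1ccc(Cl)cc1` gives 50%, within the scatter of compound 3, while compound 2 `Nc1sc(-c2ccncc2)cc1C(=O)c1ccccc1` gives 23%, beyond it. Going by the values given here, the only single-point step so far, a number 4 percentage points lower from compound 1 to compound 3 (within the scatter), concerns a different change. Compound 4 `Nc1sc(-c2ccncc2)cc1C(=O)c1ccc(Cl)cc1` differs from compound 3 by pyridin-4-yl in place of phenyl on an aromatic carbon. Among the compounds with values here, no measured step covers this change; compound 2 also carries pyridin-4-yl but differs from compound 3 in two places, so its value only hints that a lower number may follow. For compound 4 in this assay the estimate is 32%, with a range of 15% to 50%. The step of a number 14 percentage points lower from compound 3 to compound 4 (beyond the scatter) is thus expected to be downward, though with little support.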

Compound 4, a percentage reported as activity, at one concentration (the size of the read-out at that concentration, not a potency): 44%
For compound 4 the middle estimate is 12 percentage points below the measured one; measured number inside the range.
By their numbers in this assay, from the lowest: compound 2; then compounds 4, 3 and 1 (each within the scatter of the next).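

In this assay, pyridin-4-yl and phenyl on the aromatic carbon next to the ring sulfur are not told apart (a number 2 percentage points lower from compound 3 to compound 4 (within the scatter)), and pyridin-4-yl does not separate from hydrogen there either (a number 6 percentage points lower from compound 1 to compound 4 (within the scatter)). With pyridin-4-yl in place, the larger step goes with the gain of a chloro group (a number 21 percentage points higher from compound 2 to compound 4 (beyond the scatter)). No evidence on the cause of these numbers is available.

Going by these compounds, whether an amine, a carboxylic acid or a longer chain at this place would give a step beyond the scatter stays open. On these data alone, whether the chloro step holds with phenyl or hydrogen at this place also stays open.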